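Chloro to fluoro on the cyanophenyl: efficacy notes

The compounds below may be only part of what the source reports. "The series", "measured", "known", "first", "only" and "open" are said of these compounds alone.

Compound 1 `Cc1c(Nc2ccc(C#N)cc2Cl)ncnc1OC1CC2COCC(C1)N2S(=O)(=O)C1CC1`: 100%
Compound 2 `COc1c(Nc2ccc(C#N)cc2Cl)ncnc1OC1C2COCC1CN(C(=O)OC1(C)CC1)C2`: 99%

In a functional assay on HEK293 cells for agonist activity at Glucose-dependent insulinotropic receptor (Mus musculus), read by fluorescence and cAMP accumulation, with a stated time of 30 min (on this read-out lower numbers stand for smaller maximal responses and higher numbers for larger maximal responses), compound 1 gives 100% and compound 2 gives 99%; the two numbers lie within the scatter of each other, so compound 2 cannot be separated from compound 1 on the values seen. Compound 3 `COc1c(Nc2ccc(C#N)cc2F)ncnc1OC1C2COCC1CN(C(=O)OC1(C)CC1)C2` differs from compound 2 by fluoro in place of chloro on an aromatic carbon. Within the data shown here, no measured pair shows this change, so its effect is open; with both measured compounds near the ceiling, no step beyond the scatter is expected in this assay. Compound 3 is estimated at 95% (range 80% to 105%), an expected step of a number 4 percentage points lower from compound 2 to compound 3 (within the scatter).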

Compound 3, largest response reached (reported as percent of maximum), in percent of the reference or control that the assay uses: 116%
For compound 3 the middle estimate is 21 percentage points below the measured one; measured number above the stated range.
By their numbers in this assay, from the lowest: compounds 2 and 1 (each within the scatter of the next); then compound 3.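

Among these compounds, with fluoro in place of chloro on an aromatic carbon, the step of a number 17 percentage points higher from compound 2 to compound 3 (beyond the scatter) in this assay is the first one beyond the scatter. The group at this position therefore bears on the maximal response, which is not capped at the level of compound 2. Nothing shown gives a reason for this step.

Going by these compounds, whether a methyl or an amine at the same carbon would keep or lose this response remains open. Also open, on these data alone, is whether the same change carries over to compound 1, with its different core and substituents.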